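The source may report more compounds than this note shows. Statements on the series, on what has been measured and on what is new or still open speak of the compounds shown alone.

Working notes on the series.

The shared core carries an aryl group on a carbon with a double bond to nitrogen, and the two measured compounds differ there. Compound 1 `O=C(COc1cccc2ccccc12)N/N=C/c1ccc(Cl)cc1` gives 100 ug/mL in an ADME assay on HEL cells (Homo sapiens) for cytotoxicity; a higher number here means that more compound is tolerated, a lower number that less compound is tolerated. Compound 2 `COc1ccc(/C=N/NC(=O)COc2cccc3ccccc23)cc1OC` gives >= 20 ug/mL in this assay, which is a limit of the assay and not a number. Among the measured compounds shown here, compound 1 therefore stands as the only number so far, the other entry being (the limit of >= 20 ug/mL in this assay, at which 1 of the 2 values shown sits). For the measured compounds named here, no step between two measured compounds exists in this set.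

Compound 3 `O=C(COc1cccc2ccccc12)N/N=C/c1cccc(Br)c1` is not yet measured in this assay. It differs from compound 1 by 3-bromophenyl in place of 4-chlorophenyl on a carbon with a double bond to nitrogen. With one number and one limit to go on, no step beyond the scatter is expected from this change in this assay. Compound 3 is estimated at 100 ug/mL, between 50 ug/mL and 200 ug/mL, the expected step being no change at the digits printed from compound 1 to compound 3 (within the scatter).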

Compound 3, minimum cytotoxic concentration: 100 ug/mL
Beside the measured number, compound 3's estimate shows no gap at the digits printed; the range from low to high includes it.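

In this assay, among the compounds shown here, the swap of 3-bromophenyl in place of 4-chlorophenyl on a carbon with a double bond to nitrogen gives no change at the digits printed from compound 1 to compound 3 (within the scatter) and is the first step that can be read between two numbers. This position therefore takes a different halogen at a different place on the phenyl ring with the read-out held, which one number and one limit could not show. Compound 2 cannot join this comparison, its entry being a limit of the assay and not a number: the limit of >= 20 ug/mL in this assay, at which 1 of the 3 values shown sits.

The halogen and its place on the ring change together here, so their separate contributions stay unresolved. Going by these compounds, whether an amine or a carboxylic acid on this phenyl ring would hold the same read-out also remains open.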